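Hydrazone aryl changes in a glioblastoma cytotoxicity series

The compounds below may be only part of what the source reports. "The series", "measured", "known", "first", "only" and "open" are said of these compounds alone.

Measured compounds in a functional assay on U-87MG ATCC cells (Homo sapiens) for cytotoxicity, read by MTT assay, with a stated time of 72 h; a lower number here means a stronger inhibitor, a higher number a weaker inhibitor:
compound 1, `CN(C)CCn1cnnc1-c1cc(Oc2ccc(NC(=O)N/N=C/c3cccc(Br)c3)cc2F)ccn1`; compound 1 gives 830 nM
compound 2, `CN(C)CCn1cnnc1-c1cc(Oc2ccc(NC(=O)N/N=C/c3ccc(O)cc3)cc2F)ccn1`; compound 2 gives 7750 nM
compound 3, `COc1ccc(/C=N/NC(=O)Nc2ccc(Oc3ccnc(-c4nncn4CCN(C)C)c3)c(F)c2)cc1O`; compound 3 gives only a limit of the assay, > 100000 nM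

Compound 3 therefore stands at the weak end of the three, with no number of its own; its value sits at the limit of > 100000 nM in this assay, at which 1 of the 3 values shown sits. Compound 1 is the strongest of the set, and both replacements of the 3-bromophenyl on the carbon with a double bond to nitrogen raised the number: a 9.3-fold higher number from compound 1 to compound 2 (0.97 log units; beyond the scatter), and an at least 120-fold higher number from compound 1 to compound 3 (2.08 log units; beyond the scatter). Between the two oxygenated rings, an at least 12-fold higher number from compound 2 to compound 3 (1.11 log units; beyond the scatter).

Compound 4, `COc1cc(/C=N/NC(=O)Nc2ccc(Oc3ccnc(-c4nncn4CCN(C)C)c3)c(F)c2)cc(OC)c1OC`, differs from compound 3 by 3,4,5-trimethoxyphenyl in place of 3-hydroxy-4-methoxyphenyl on a carbon with a double bond to nitrogen. Going by the values given here, the steps that bear on it are the two that lead into compound 3, each showing that extra oxygen substitution on this ring weakened the compound; compound 4 adds a further methoxy and removes the hydroxyl. Compound 4 is therefore expected to remain at or near the limit in this assay, with a number no higher from compound 3 to compound 4 (the limit leaves the size open) as the expected step. The estimate for compound 4 is 100000 nM, in the range 20000 nM to 300000 nM.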

Compound 4, half-maximal inhibitory concentration: 22500 nM
Compound 4: middle estimate off by 4.4-fold (0.65 log units), on the high side; the range from low to high includes it.
By their numbers in this assay, from the lowest: compound 1; then compound 2; then compound 4. At a limit, above all of these: compound 3.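

In this assay, further oxygen substitution on the ring at the carbon with a double bond to nitrogen does not by itself drive the number to the limit, as 3,4,5-trimethoxyphenyl in place of 3-hydroxy-4-methoxyphenyl gives an at least 4.4-fold lower number from compound 3 to compound 4 (0.64 log units; beyond the scatter). The oxygenated rings therefore do not form a simple trend of more oxygen and weaker compounds, with compound 4 going against it, yet 3,4,5-trimethoxyphenyl still gives a 2.9-fold higher number from compound 2 to compound 4 (0.46 log units; beyond the scatter) and a 27-fold higher number from compound 1 to compound 4 (1.43 log units; beyond the scatter), which leaves 3-bromophenyl ahead of all the oxygenated rings shown. The value of compound 3 is a limit, and the true size of the step into compound 4 stays open because only a bound exists for compound 3: the limit of > 100000 nM in this assay, at which 1 of the 4 values shown sits.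

The change to compound 4 removes the hydroxyl and adds methoxy groups at once, so the step cannot be assigned to either alone, and a 3,4-dimethoxyphenyl ring would help to separate the two. Also open, as far as these compounds go, is whether the lower number of compound 1 is specific to bromine, which a 3-chlorophenyl or an unsubstituted phenyl ring at the same place would test.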